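Furan-3-yl in place of thiophen-2-yl: working notes

The source may report more compounds than this note shows. Statements on the series, on what has been measured and on what is new or still open speak of the compounds shown alone.

Measured in a functional assay on the whole organism for inhibition, with Rattus norvegicus as the target; a higher number here means a weaker inhibitor, a lower number a stronger inhibitor
- compound 1 (`COc1ccccc1C1=NOC(=O)/C1=C\c1cccs1`) gives 7100 nM
- compound 2 (`O=C1ON=C(c2cccs2)/C1=C/c1ccccc1`) gives 4400 nM
- compound 3 (`O=C1ON=C(c2cccs2)/C1=C/c1cccs1`) gives 3700 nM

In this assay compound 3 lies within the scatter of both compound 2 and compound 1, so the numbers do not set it apart. Compound 4 (`O=C1ON=C(c2cccs2)/C1=C/c1ccoc1`) carries one change on a double-bonded chain carbon bound to a double-bonded ring carbon: furan-3-yl in place of thiophen-2-yl on a double-bonded chain carbon bound to a double-bonded ring carbon is the whole difference. Among the measured compounds shown here, the one measured step at this place (a 1.2-fold lower number from compound 2 to compound 3 (0.08 log units; within the scatter)) stayed within the scatter, with thiophen-2-yl in place of phenyl. For the measured compounds named here, no furan-3-yl compound has been measured yet, so the evidence is thin. The estimated step (a 1.1-fold higher number from compound 3 to compound 4 (0.03 log units; within the scatter)) is therefore expected to stay within the scatter, in neither direction. Compound 4 is expected at 4000 nM (estimated range 1800 nM to 9000 nM).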

Compound 4, half-maximal inhibitory concentration: 3600 nM
Estimate against measurement, compound 4: 1.1-fold (0.05 log units) above; the measured number falls inside the stated range.
By their numbers in this assay, from the lowest: compounds 4, 3, 2 and 1 (each within the scatter of the next).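

At the double-bonded chain carbon, furan-3-yl in place of thiophen-2-yl gives a 1.0-fold lower number from compound 3 to compound 4 (0.01 log units; within the scatter), and furan-3-yl in place of phenyl gives a 1.2-fold lower number from compound 2 to compound 4 (0.09 log units; within the scatter). Compounds 2, 3 and 4 therefore show that, in this assay, this place accepts an oxygen-containing five-membered aromatic ring as well as the sulfur-containing ring and phenyl, with no separation among the three. Nothing available explains this closeness.

Going by these compounds, whether an amine, a carboxylic acid or a longer chain at this place would stay in the same range remains open.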